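Naphthyl for methoxyphenyl at the isoxazole-bearing position

A few compounds are considered here, and "the series" means these few. Any claim that something is new, unique, unknown or untested is made for them only; others in the source may bear on it.

Measured so far in a functional assay on A549 cells (Homo sapiens) for inhibition, read by MTT assay, with a stated time of 24 h; a lower number here means a stronger inhibitor, a higher number a weaker inhibitor:
- compound 1 `O=C(O)C1=Cc2ccccc2OC1(OCc1cc(-c2ccc([N+](=O)[O-])cc2)no1)C(F)(F)F`, which reaches only the limit > 150000 nM.
- compound 2 `O=C(O)C1=Cc2ccccc2OC1(OCc1cc(-c2ccc(F)cc2F)no1)C(F)(F)F`, also reported only as the limit > 150000 nM.
- compound 3 `COc1ccc(-c2cc(COC3(C(F)(F)F)Oc4ccccc4C=C3C(=O)O)on2)cc1`, which gives 36200 nM.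

Among the compounds with values here, compound 3 carries the only real number in this assay; the other two values are limits (the limit of > 150000 nM in this assay, at which 2 of the 3 values shown sit). The steps into compound 3 are therefore readable only as bounds: an at least 4.1-fold lower number from compound 1 to compound 3 (0.61 log units; beyond the scatter) and an at least 4.1-fold lower number from compound 2 to compound 3 (0.61 log units; beyond the scatter). The pair of compounds 1 and 2 shows two limits and nothing between them.

Compound 4 `O=C(O)C1=Cc2ccccc2OC1(OCc1cc(-c2ccc3ccccc3c2)no1)C(F)(F)F` has not yet been measured in this assay. Its change from compound 3 is naphthalen-2-yl in place of 4-methoxyphenyl on an aromatic carbon. Within the data shown here, no measured step replaces one aryl group with a fused bicyclic one; the measured steps only show that 4-methoxyphenyl on this ring gives a readable number where 4-nitrophenyl and 2,4-difluorophenyl do not. The step to compound 4 is expected to fall within a small range around no change, with a real risk that it returns to a limit: a 1.7-fold higher number from compound 3 to compound 4 (0.22 log units; within the scatter). Compound 4 is estimated at 60000 nM, between 15000 nM and 200000 nM.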

Compound 4, half-maximal inhibitory concentration: > 150000 nM
Compound 4: a limit, no number; the forecaster's own chance of this, stated with the estimate: 40%; at least 2.5-fold (0.39 log units) between middle value and limit.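

In this assay, naphthalen-2-yl in place of 4-methoxyphenyl on the aromatic carbon next to the ring nitrogen gives an at least 4.1-fold higher number from compound 3 to compound 4 (0.61 log units; beyond the scatter). Within the data shown here, the step shows that an aromatic group at this position does not give a readable number merely by carrying no nitro or fluoro substituent: the carbon-only naphthalen-2-yl group falls with 4-nitrophenyl and 2,4-difluorophenyl, leaving 4-methoxyphenyl in compound 3 as the only group here with a number. The steps from compound 1 and from compound 2 to compound 4 cannot be read, as each joins two limits, and the comparison across this position now rests on a single number: the limit of > 150000 nM in this assay, at which 3 of the 4 values shown sit.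

Going by these compounds, it remains open whether the readable number of compound 3, at 36200 nM, goes with the methoxy oxygen or with the single six-membered ring, a question that 4-hydroxyphenyl, 4-ethoxyphenyl or 4-methylphenyl at the same position would address. Also open, on these data alone, is whether any group at this position gives a number well below that of compound 3, and what an amide in place of the carboxylic acid on the shared core would do in this assay.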